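The source may report more compounds than this note shows. Statements on the series, on what has been measured and on what is new or still open speak of the compounds shown alone.

Of the compounds shown here, three built on one shared core have been measured in an assay on isolated protein for inhibition of sphingomyelin phosphodiesterase (Homo sapiens), read by fluorescence, with a stated time of 30 min; a higher number here means a weaker inhibitor, a lower number a stronger inhibitor. Compound 1 `CCCCCCc1ccc(COc2cccc(C(=O)NO)c2)cc1` carries a hexyl group and gives 2110 nM. Compound 2 `O=C(NO)c1cccc(OCc2ccc(-c3ccccc3)cc2)c1` has a phenyl group at that position, and in this assay compound 2 gives 19600 nM. Compound 3 `O=C(NO)c1cccc(OCc2ccc(-c3cccnc3)cc2)c1` bears a pyridin-3-yl group; in this assay compound 3 gives 52300 nM, the highest of the three numbers and therefore the weakest inhibitor among them.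

Compound 4 `O=C(NO)c1cccc(OCc2ccc(/C=C/c3ccccc3)cc2)c1` has not yet been measured. It differs from compound 3 in one place: 2-phenylethenyl in place of pyridin-3-yl on an aromatic carbon. For the measured compounds named here, two measured steps bear on this change. Removing the ring nitrogen is the reverse of the step of a 2.7-fold higher number from compound 2 to compound 3 (0.43 log units; beyond the scatter), and a longer all-carbon group is closer to the hexyl of compound 1, recalling the step of a 25-fold higher number from compound 1 to compound 3 (1.39 log units; beyond the scatter). A clear move to a lower number is therefore expected, though the hexyl of compound 1 is not reproduced. Compound 4 is expected to give about 6000 nM, between 1500 nM and 25000 nM, which amounts to an expected step of an 8.7-fold lower number from compound 3 to compound 4 (0.94 log units; beyond the scatter).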

Compound 4, half-maximal inhibitory concentration: > 100000 nM
Compound 4: only a limit was reported; the forecaster's own chance of this, stated with the estimate: 5%; middle value at least 16-fold (1.22 log units) away from the limit.
By their numbers in this assay, from the lowest: compound 1; then compound 2; then compound 3. At a limit, above all of these: compound 4.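

In this assay, compound 4 gives only a limit of the assay, not a number: the limit of > 100000 nM in this assay, at which 1 of the 4 values shown sits.

Replacing hexyl with 2-phenylethenyl gives an at least 47-fold higher number from compound 1 to compound 4 (1.67 log units; beyond the scatter), and replacing phenyl with it gives an at least 5.1-fold higher number from compound 2 to compound 4 (0.70 log units; beyond the scatter), so on this aromatic carbon, para to a large group, an all-carbon group does not by that alone come close to hexyl. Against pyridin-3-yl, the change gives an at least 1.9-fold higher number from compound 3 to compound 4 (0.28 log units; that floor lies within the scatter), so the order of compound 3 and compound 4 stays unsettled.

The compounds shown leave open whether a shorter chain such as butyl, a longer chain such as octyl, or a 2-phenylethyl group, which lacks the double bond, would read nearer to hexyl or to 2-phenylethenyl. They also leave open how an amine or a carboxylic acid on this same aromatic carbon would read.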